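Pyridyl group change on the shared core: compound 3 to compound 4

The source may hold more compounds than are shown below. What is called first, only, known or untested is meant among the compounds shown, and "the series" means these compounds.

Measured so far:
compound 1 `CCCN(CCC)c1cc(C)nc2c(-c3ncc(C(F)(F)F)cc3Cl)c(C)nn12` — 1.2 nM
compound 2 `CCCCN(CCC)c1cc(C)nc2c(-c3ncc(C(F)(F)F)cc3Cl)c(C)nn12` — 1.2 nM
compound 3 `CCCN(CCC)c1cc(C)nc2c(-c3ncc(N)cc3C)c(C)nn12` — 85 nM

All numbers come from an assay on isolated protein for binding affinity to corticotropin-releasing factor receptor 1 (Homo sapiens); a lower number here means a stronger inhibitor, a higher number a weaker inhibitor. Compound 1 and compound 2 give the same result within the scatter; the step of no change at the digits printed from compound 1 to compound 2 (within the scatter) touches only the chain on the ring nitrogen. Compound 3, which carries the 5-amino-3-methylpyridin-2-yl group, gives the highest number of the three, and its gap to compound 1 and to compound 2 lies well beyond the scatter.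

Compound 4 `CCCN(CCC)c1cc(C)nc2c(-c3ncc(C)cc3N=O)c(C)nn12` differs from compound 3 in the aromatic group on the core: a group of 9 heavy atoms (6 carbon, 2 nitrogen, 1 oxygen; one six-membered aromatic ring with 1 hetero atom) in place of a group of 8 heavy atoms (6 carbon, 2 nitrogen; one six-membered aromatic ring with 1 hetero atom), on an aromatic carbon. Within the data shown here, no measured step is of this kind. Among the measured compounds shown here, the single step, from compound 1 to compound 2, leaves the aromatic group unchanged and so does not bear on the present change. For the measured compounds named here, the comparison of compound 1 with compound 3 shows only that the aromatic group can move the number by a large amount in this assay; it gives no direction for the exchange of the amino-bearing group for the nitroso-bearing one. In the absence of a guiding step, compound 4 is expected to remain near compound 3, with a wide range, at an estimated 120 nM (from 20 nM to 700 nM). The expected step is a 1.4-fold higher number from compound 3 to compound 4 (0.15 log units; within the scatter).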

Compound 4, inhibition constant: > 10000 nM
Compound 4 gave a limit, no number (the forecaster's own chance of this, stated with the estimate: 10%); at least 83-fold (1.92 log units) between middle value and limit.
By their numbers in this assay, from the lowest: compounds 1 and 2 (each within the scatter of the next); then compound 3. At a limit, above all of these: compound 4.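

Exchanging the 5-amino-3-methylpyridin-2-yl group for the nitroso-bearing group on the shared core gives an at least 110-fold higher number from compound 3 to compound 4 (2.07 log units; beyond the scatter) in this assay, so a six-membered aromatic ring with 1 hetero atom at this place does not by itself secure a readable value. Compound 4 gives a limit, not a number: the limit of > 10000 nM in this assay, at which 1 of the 4 values shown sits. The earlier compounds shown here showed that the aromatic group could move the result, but each still gave a number, including compound 3 at 85 nM.

Going by these compounds, it remains open whether the nitroso group itself or the changed arrangement of groups on the pyridine ring sets this step; a nitro, methoxy or nitrile group in its place would help to separate the two. On these data alone, it is also open whether the butyl chain of compound 2 would behave the same way with these pyridyl groups.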